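Swapping the aryl group on a shared core

The compounds below may be only part of what the source reports. "The series", "measured", "known", "first", "only" and "open" are said of these compounds alone.

Of the compounds shown here, three built on one shared core have been tested in a functional assay on U-87MG ATCC cells for antiproliferative activity against U-87 MG (Homo sapiens), read by MTT assay, with a stated time of 48 h, tested at 50 uM; a higher number here means a weaker effect of the compound at the concentration tested, a lower number a stronger effect. Compound 1 `Cc1nc(-c2ccc(Cl)cc2)sc1C(=O)CSc1nc(-c2ccccc2)c(C#N)c(=O)[nH]1` gives 41.6%. Compound 2 `COc1ccc(-c2nc(SCC(=O)c3sc(-c4ccccc4)nc3C)[nH]c(=O)c2C#N)cc1` gives 52.1%. Compound 3 `Cc1nc(-c2ccc(Cl)cc2)sc1C(=O)CSc1nc(-c2cccc(Cl)c2)c(C#N)c(=O)[nH]1` gives 52.6%, the highest of the three numbers: it sits within the scatter of compound 2 and beyond the scatter of compound 1. Within the data shown here, the only single-point step measured is a number 11 percentage points higher from compound 1 to compound 3 (beyond the scatter), a modest weakening.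

Compound 4 `COc1ccc(-c2nc(SCC(=O)c3sc(-c4ccc(Cl)cc4)nc3C)[nH]c(=O)c2C#N)cc1` has not yet been measured in this assay. Its change from compound 3 is 4-methoxyphenyl in place of 3-chlorophenyl on an aromatic carbon. Among the measured compounds shown here, no measured step covers this exact exchange. Compound 2 carries the same 4-methoxyphenyl group as compound 4, but on a different partner ring, so it differs from compound 3 in two places, and its number lies within the scatter of compound 3. The step from compound 1 to compound 3 shows that changing this aryl group can move the number modestly, yet that step replaced hydrogen with chloro, not chloro with methoxy. The step from compound 3 to compound 4 is therefore expected to be small, if any, a number 1.4 percentage points higher from compound 3 to compound 4 (within the scatter). Compound 4 is estimated at 54%, with a range from 40% to 68%.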

Compound 4, a percentage reported as activity, at one concentration (the size of the read-out at that concentration, not a potency): 46.3%
Compound 4: middle estimate off by 7.7 percentage points, on the high side; the measured number falls inside the stated range.
By their numbers in this assay, from the lowest: compounds 1, 4, 2 and 3 (each within the scatter of the next, the first and the last beyond it).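

The exchange of 3-chlorophenyl for 4-methoxyphenyl at this position gives a number 6.3 percentage points lower from compound 3 to compound 4 (within the scatter), so this assay does not tell these two groups apart. Methoxy in place of hydrogen on the phenyl group at the same position gives a number 4.7 percentage points higher from compound 1 to compound 4 (within the scatter), which shows that a substituent on this aryl group does not have to move the number beyond the scatter, as the chloro of compound 3 did. Chloro in place of hydrogen on the other aryl group gives a number 5.8 percentage points lower from compound 2 to compound 4 (within the scatter), so this exchange does not carry one fixed size from one core to the other: the same change on two cores in this assay, a number 11 percentage points higher (beyond the scatter) from compound 1 to compound 3 and a number 5.8 percentage points lower (within the scatter) from compound 2 to compound 4, 16.8 percentage points apart, beyond the scatter of two such steps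

As far as these compounds go, it remains open whether other groups on this aryl ring, such as an amine or a carboxylic acid, would shift the number beyond the scatter. The effect of a group also remains tied up with its place on the ring, as 3-chlorophenyl and 4-methoxyphenyl differ in both, and separating the two would take a 4-chlorophenyl or a 3-methoxyphenyl group at this position on the same core.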